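From Ethoxycarbonyl to (Piperidin-1-yl)carbonyl at the Chain End

A few compounds are considered here, and "the series" means these few. Any claim that something is new, unique, unknown or untested is made for them only; others in the source may bear on it.

Three compounds have been measured in an assay on AV12 cells for binding affinity to Neuropeptide Y receptor type 1 (Homo sapiens); a higher number here means a weaker inhibitor, a lower number a stronger inhibitor:

Compound 1 `CCCN1CCC(CCCn2c(COc3ccc(Cl)cc3)nc3c(C)cccc32)CC1`: 29 nM
Compound 2 `Cc1cccc2c1nc(COc1ccc(Cl)cc1)n2CCCC1CCN(CCCc2ccccc2)CC1`: 57 nM
Compound 3 `CCOC(=O)CCCN1CCC(CCCn2c(COc3ccc(Cl)cc3)nc3c(C)cccc32)CC1`: 29 nM

The three share one core and differ only at the end of the chain that hangs from the ring amine nitrogen. Compound 3 reads the same as compound 1, and the step of a 2.0-fold lower number from compound 2 to compound 3 (0.29 log units; within the scatter) is within the scatter, so all three numbers count as one level.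

Compound 4 `Cc1cccc2c1nc(COc1ccc(Cl)cc1)n2CCCC1CCN(CCCC(=O)N2CCCCC2)CC1` is the next change at that chain end: piperidin-1-yl in place of ethoxy on a carbonyl carbon. Within the data shown here, the steps that bear on it all sit at this same place: no change at the digits printed from compound 1 to compound 3 (within the scatter), a 2.0-fold higher number from compound 1 to compound 2 (0.29 log units; within the scatter), and a 2.0-fold lower number from compound 2 to compound 3 (0.29 log units; within the scatter). None of them moved the number beyond the scatter, whether hydrogen, phenyl or ethoxycarbonyl ended the chain. On that record no step beyond the scatter is expected in this assay for compound 4 either, in either direction, and the expected step is no change at the digits printed from compound 3 to compound 4 (within the scatter). The estimate for compound 4 is 29 nM, with a range from 12 nM to 70 nM.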

Compound 4, inhibition constant: 21 nM
For compound 4 the middle estimate is 1.4-fold (0.14 log units) above the measured one; measured number inside the range.
By their numbers in this assay, from the lowest: compounds 4, 1, 3 and 2 (each within the scatter of the next, the first and the last beyond it).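

On the carbonyl carbon, the six-membered non-aromatic ring of piperidin-1-yl can replace ethoxy with a 1.4-fold lower number from compound 3 to compound 4 (0.14 log units; within the scatter), and the whole (piperidin-1-yl)carbonyl group can replace hydrogen with a 1.4-fold lower number from compound 1 to compound 4 (0.14 log units; within the scatter). Among these compounds, the new finding is a 2.7-fold lower number from compound 2 to compound 4 (0.43 log units; beyond the scatter), the first step at this chain end to lie beyond the scatter in this assay, though only modestly, so the group here is not wholly without consequence. Compound 2 and compound 4 now stand apart, while compound 1 and compound 3 remain within the scatter of both, and nothing measured here gives a reason for that gap.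

Still open, on these data alone, is whether a carboxylic acid in place of the ethoxy would stay at this level. A longer chain between the carbonyl and the ring amine nitrogen is equally untested among the compounds shown.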